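The compounds below may be only part of what the source reports. "The series", "measured", "known", "first", "only" and "open" are said of these compounds alone.

Compound 1 `COc1c(N2CC[C@@H](CO)C2)c(F)cc2c(=O)c(C(=O)O)cn(Cc3ccc(-c4ccccc4)cc3)c12` carries a 3-(hydroxymethyl)pyrrolidin-1-yl group on the shared core. In an assay on isolated protein for inhibition of DNA topoisomerase 1 (Homo sapiens), with a stated time of 15 min (a higher number here means a weaker inhibitor, a lower number a stronger inhibitor), compound 1 gives > 200000 nM, which is a limit of the assay and not a number. The series also holds compound 2 `COc1c(N2CC[C@@H](CN)C2)c(F)cc2c(=O)c(C(N)=O)cn(Cc3ccc(-c4ccccc4)cc3)c12`, which in this assay gives 184000 nM. Compound 1 therefore stands at the limit of the measured range, as the limit of > 200000 nM in this assay, at which 1 of the 2 values shown sits, shows.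

Compound 3 `COc1c(N2CC[C@@H](C(N)=O)C2)c(F)cc2c(=O)c(C(=O)O)cn(Cc3ccc(-c4ccccc4)cc3)c12` differs from compound 1 by carbamoyl in place of hydroxymethyl on a saturated ring carbon. Within the data shown here, no pair of measured compounds differing in one place is available, so the size of this step in this assay is not known from measurement. The two values shown both sit at the weak end, and for compound 3 no step beyond the usual scatter is expected. The estimate for compound 3 in this assay is 200000 nM, with a range from 100000 nM to 400000 nM. The expected step is a number no higher from compound 1 to compound 3 (the limit leaves the size open).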

Compound 3, half-maximal inhibitory concentration: > 200000 nM
Compound 3 was reported as a limit; the forecaster's own chance of this, stated with the estimate: 60%; the middle value sits exactly at the limit.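

In this assay no step can be read from compound 1 to compound 3, as both values are limits of the assay and not numbers: the limit of > 200000 nM in this assay, at which 2 of the 3 values shown sit.

The compounds shown leave open whether carbamoyl in place of hydroxymethyl on a saturated ring carbon shifts the value at all.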